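The source may report more compounds than this note shows. Statements on the series, on what has been measured and on what is new or still open speak of the compounds shown alone.

Values in a functional assay on CCRF-CEM cells (Homo sapiens) for antiproliferative activity; on this read-out higher numbers stand for weaker inhibition of growth and lower numbers for stronger inhibition of growth:
- compound 1 `COCCCCCCCCCCCCCCC/C=C1/CC(CO)(COC(=O)C(C)(C)C)OC1=O`: < 0.1 ug/mL, a limit of the assay
- compound 2 `COCCCCCCCCCCC/C=C1\CC(CO)(COC(=O)C(C)(C)C)OC1=O`: 0.701 ug/mL
- compound 3 `CCCCCCCCC(O)CCCCCC/C=C1\CC(CO)(COC(=O)C(C)(C)C)OC1=O`: 5.72 ug/mL

Compound 1 gives only a limit, not a number (the limit of < 0.1 ug/mL in this assay, at which 1 of the 3 values shown sits). Of the two actual numbers, the higher belongs to compound 3, and the shift is an 8.2-fold higher number from compound 2 to compound 3 (0.91 log units; beyond the scatter).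

Next in the series is compound 4 `CC(C)(C)C(=O)OCC1(CO)C/C(=C\CCCCCCCCCCCCCCC=O)C(=O)O1`, with the change 8-formyloctyl in place of 1-hydroxynonyl on a saturated chain carbon, six bonds along the chain from a double-bonded chain carbon.

Among the measured compounds shown here, only one measured step changes this same place, namely an 8.2-fold higher number from compound 2 to compound 3 (0.91 log units; beyond the scatter). It brought 1-hydroxynonyl in, and the change to compound 4 takes that group out again. Part of that shift is therefore expected to be undone in this assay, giving a lower number but a smaller step than the measured one. A single step is thin support, so the range stays wide.

The expected step is a 3.2-fold lower number from compound 3 to compound 4 (0.50 log units; beyond the scatter). For compound 4 the estimated value is 1.8 ug/mL, with an expected range of 0.4 ug/mL to 7 ug/mL.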

Compound 4, concentration for 50% growth inhibition: 0.933 ug/mL
Compound 4: middle estimate off by 1.9-fold (0.29 log units), on the high side; the range from low to high includes it.
By their numbers in this assay, from the lowest: compounds 2 and 4 (each within the scatter of the next); then compound 3. At a limit, below all of these: compound 1.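

In this assay the change to 8-formyloctyl gives a 6.1-fold lower number from compound 3 to compound 4 (0.79 log units; beyond the scatter), so at this place, on a saturated chain carbon, six bonds along the chain from a double-bonded chain carbon, the higher number does not carry over from 1-hydroxynonyl to every oxygen-bearing group. The formyl-ended chain and the methoxy-ended chain cannot be told apart, with a 1.3-fold higher number from compound 2 to compound 4 (0.12 log units; within the scatter), which leaves compound 3 alone with the higher number among the three actual values. Nothing given here accounts for the difference between these groups.

On these data alone, whether a carboxylic acid or an amine at this place would follow compound 3 or compound 4 stays open. Among the compounds shown here, compound 1 gives < 0.1 ug/mL, which is a limit and not a number, and so sets no size for any step.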